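The source may report more compounds than this note shows. Statements on the series, on what has been measured and on what is new or still open speak of the compounds shown alone.

Measured compounds:
- Compound 1, `COc1cc(-c2nn(-c3ccc(NC(=O)Nc4ccc(Cl)c(C(F)(F)F)c4)cc3)cc2-c2ccncc2)ccc1Cl`, in a functional assay on UACC-257 cells (Homo sapiens) for antiproliferative activity, read by sulforhodamine B assay, with a stated time of 48 h (on this read-out lower numbers stand for stronger inhibition and higher numbers for weaker inhibition), compound 1 gives 1640 nM.
- Compound 2, `COc1cc(-c2nn(-c3ccc(NC(=O)Nc4cc(C(F)(F)F)cc(C(F)(F)F)c4)cc3)cc2-c2ccncc2)ccc1Cl`, in this assay compound 2 gives 2300 nM.

Compound 2 sits at the upper end of these two numbers, but the gap to compound 1 lies within the scatter of repeated measurements, so the two cannot be ranked against each other.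

Compound 3, `O=C(Nc1ccc(-n2cc(-c3ccncc3)c(-c3ccc(Cl)c(O)c3)n2)cc1)Nc1cc(C(F)(F)F)cc(C(F)(F)F)c1`, is compound 2 with one change: hydrogen in place of methyl on an oxygen on an aromatic ring. Going by the values given here, no measured pair shows this change, so nothing directly tells how large a step it brings. Among the compounds with values here, with only two compounds, both within the scatter of one another, the expectation is that the step from methoxy to hydroxy stays within the scatter, with no direction that can be justified. Compound 3 is therefore expected to give 2300 nM, in a range from 800 nM to 6500 nM, which means an estimated step of no change at the digits printed from compound 2 to compound 3 (within the scatter).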

Compound 3, half-maximal inhibitory concentration: 2010 nM
Compound 3: the middle estimate sits 1.1-fold (0.06 log units) above what was measured, and the stated range covers the measured number.
By their numbers in this assay, from the lowest: compounds 1, 3 and 2 (each within the scatter of the next).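

Going by these compounds alone, putting hydrogen in place of methyl on an oxygen on an aromatic ring gives, in this assay, a 1.1-fold lower number from compound 2 to compound 3 (0.06 log units; within the scatter) and so gives the first reading of a single change. At this position, methoxy and hydroxy cannot be told apart on this read-out, and the 4-chloro-3-hydroxyphenyl group keeps compound 3 in the same micromolar region as compound 2. The compounds shown offer no measurement that explains this outcome.

From the compounds shown here alone, it remains open whether this position stays as undemanding with other groups, such as a longer chain like ethyl on the oxygen or an amine in place of the hydroxy. Going by these compounds, it is also open whether the change from methoxy to hydroxy would read the same with compound 1 as the starting point.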